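This account rests on a few compounds, and the source may have more. Where it says the series, first, only, none or still open, it means among the compounds named here.

Measured so far:
compound 1 `O=C(O)c1cc(Br)cc2c(=O)cc(-c3cccc(/C=C/c4ccc5ccccc5n4)c3)oc12`: 100 nM
compound 2 `O=C(O)c1cc(Cl)cc2c(=O)cc(-c3cccc(/C=C/c4ccc5ccccc5n4)c3)oc12`: 15 nM

In a functional assay on the whole organism (ileum) for inhibition, with Cavia porcellus as the target (a lower number here means a stronger inhibitor, a higher number a weaker inhibitor), compound 1 gives 100 nM, and compound 2 gives 15 nM. Among the compounds with values here, compound 2 thus stands with the lowest of the two numbers, set apart from compound 1 by a 6.7-fold lower number from compound 1 to compound 2 (0.82 log units; beyond the scatter), the only step in hand, which arises from chloro in place of bromo on an aromatic carbon. Compound 3 `Cc1cc(C(=O)O)c2oc(-c3cccc(/C=C/c4ccc5ccccc5n4)c3)cc(=O)c2c1` differs from compound 2 by methyl in place of chloro on an aromatic carbon. Within the data shown here, no measured step covers an exchange of chloro for methyl; the one step available, a 6.7-fold lower number from compound 1 to compound 2 (0.82 log units; beyond the scatter), bears on it only by showing that the group on that aromatic carbon can shift the number in this assay beyond the scatter. Among the measured compounds shown here, with no closer precedent, the step is expected to be small, a 2.0-fold higher number from compound 2 to compound 3 (0.30 log units; within the scatter), toward a somewhat higher number. Compound 3 is therefore estimated at 30 nM, with a range from 8 nM to 120 nM.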

Compound 3, half-maximal inhibitory concentration: 28 nM
Estimate against measurement, compound 3: 1.1-fold (0.03 log units) above; low and high end bracket the measured number.
By their numbers in this assay, from the lowest: compounds 2 and 3 (each within the scatter of the next); then compound 1.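

Against chloro, methyl on this aromatic carbon, meta to a carboxy group, gives (a 1.9-fold higher number from compound 2 to compound 3 (0.27 log units; within the scatter)) in this assay, so the two groups cannot be told apart here, something the single bromo-to-chloro step could not show. Methyl also stands clear of bromo, with (a 3.6-fold lower number from compound 1 to compound 3 (0.55 log units; beyond the scatter)) as the step, so the distance from compound 1 is not peculiar to chloro: compound 2 and compound 3 both lie beyond the scatter from it. Nothing available accounts for why bromo stands apart from the other two groups.

On these data alone, three groups at one position give only a narrow view, and it remains open whether fluoro, methoxy or trifluoromethyl would stay with chloro and methyl or fall with bromo. Also open, as far as these compounds go, is how the shared core would respond with only hydrogen on this carbon.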